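Trifluoromethyl for Fluoro on the Fused Ring of Compound 2

This account rests on a few compounds, and the source may have more. Where it says the series, first, only, none or still open, it means among the compounds named here.

Of the compounds shown here, three have been measured in a functional assay on CHO cells for antagonist activity at sphingosine 1-phosphate receptor 2 (Homo sapiens), read by calcium flux; on this read-out lower numbers stand for stronger inhibition and higher numbers for weaker inhibition. Compound 1 `CCOc1cc2nn(Cc3nn(CC(=O)O)c(=O)c4ccccc34)cc2cc1Cl` reaches only a limit in this assay, > 6640 nM. Compound 2 `O=C(O)Cn1nc(Cc2nc3cc(F)c(OCC4CC4)cc3[nH]2)c2ccccc2c1=O` gives 18 nM, and compound 3 `CC(C)(C(=O)O)c1nn(Cc2cn3cc(OCC4CC4)c(Cl)cc3n2)c2ccccc2c1=O` gives 7.7 nM; compound 2 thus holds the higher of the two numbers, and its gap to compound 3 lies beyond the scatter of this assay. Compound 4 `O=C(O)Cn1nc(Cc2nc3cc(C(F)(F)F)c(OCC4CC4)cc3[nH]2)c2ccccc2c1=O` carries trifluoromethyl in place of fluoro on an aromatic carbon. Among the compounds with values here, no measured pair shows this change on its own, so its effect can only be estimated. A small step is expected, within the usual scatter of this assay and without a clear direction; the step this estimate means is a 1.2-fold lower number from compound 2 to compound 4 (0.08 log units; within the scatter). Compound 4 is therefore estimated at 15 nM, between 5 nM and 50 nM.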

Compound 4, half-maximal inhibitory concentration: 6.6 nM
Beside the measured number, compound 4's estimate is 2.3-fold (0.36 log units) above it, within the range that was stated.
By their numbers in this assay, from the lowest: compounds 4 and 3 (each within the scatter of the next); then compound 2. At a limit, above all of these: compound 1.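

In this assay, within the data shown here, this is the first change read at a single place, and it shows that the substituent on the aromatic carbon ortho to a cyclopropylmethoxy group affects the result: a 2.7-fold lower number from compound 2 to compound 4 (0.44 log units; beyond the scatter). Trifluoromethyl, with its 4 heavy atoms, is thus accepted here in place of fluoro, with no loss of inhibition. None of the evidence shown bears on the cause of this step. From the compounds shown here alone, it remains open how a nitrile or a methoxy group on this carbon would compare, and whether the same step holds on the core of compound 3.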